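Removing one hydroxy from the dihydroxyphenyl arm of compound 2

A few compounds are considered here, and "the series" means these few. Any claim that something is new, unique, unknown or untested is made for them only; others in the source may bear on it.

Among the compounds with values here, in a functional assay (Mus musculus) for inhibition, with a stated time of 5 days (on this read-out higher numbers stand for weaker inhibition and lower numbers for stronger inhibition), compound 2 `CCOC(=O)/C=C/c1cn(-c2ccc(O)cc2)nc1-c1ccc(O)c(O)c1` gives 6200 nM, the lowest of the two numbers measured so far. Compound 1 `O=Cc1cn(-c2ccc(O)cc2)nc1-c1ccc(O)cc1`, the aldehyde with two 4-hydroxyphenyl groups, gives 44000 nM in this assay, a higher number that lies beyond the scatter. Within the data shown here, compound 1 and compound 2 differ in two places at once, so the two values show only that compound 2 inhibits more strongly, not which change carries the gain.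

Compound 3 `CCOC(=O)/C=C/c1cn(-c2ccc(O)cc2)nc1-c1ccc(O)cc1` keeps the ethyl ester chain of compound 2 and changes the aryl arm: hydrogen in place of hydroxy on an aromatic carbon Cut one bond further out, this reads as 3,4-dihydroxyphenyl to 4-hydroxyphenyl. Among the measured compounds shown here, no measured pair isolates this change, so there is nothing to set a step against; the hydroxy that leaves is a donor and an acceptor, and its loss is expected to cost some inhibition rather than none.

Expected is a 2.1-fold higher number from compound 2 to compound 3 (0.32 log units; beyond the scatter), a modest step toward a higher number, beyond the scatter but not large. Compound 3 is estimated at 13000 nM, with a range from 5000 nM to 35000 nM.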

Compound 3, half-maximal inhibitory concentration: 25000 nM
For compound 3 the middle estimate is 1.9-fold (0.28 log units) below the measured one; low and high end bracket the measured number.
By their numbers in this assay, from the lowest: compound 2; then compounds 3 and 1 (each within the scatter of the next).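

In this assay, the hydroxy ortho to a hydroxy group now has a step of its own: hydrogen in its place gives a 4.0-fold higher number from compound 2 to compound 3 (0.61 log units; beyond the scatter), a modest loss of inhibition beyond the scatter that shows the 3,4-dihydroxyphenyl arm counts for more than the 4-hydroxyphenyl arm on the ethyl ester chain. With the 4-hydroxyphenyl arm held constant, 2-(ethoxycarbonyl)ethenyl in place of formyl gives a 1.8-fold lower number from compound 1 to compound 3 (0.25 log units; within the scatter), which lies within the scatter, so this chain change shows no effect that can be told apart from repeat variation. Together, the two steps place the readable effect in this small set on the hydroxy rather than on the chain, although no available data bear on why that hydroxy matters.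

From the compounds shown here alone, it remains open whether the chain change would also stay within the scatter on the 3,4-dihydroxyphenyl arm, which a formyl compound carrying that arm would test. Also open, going by these compounds, is whether the hydroxy can be replaced by a methoxy or an amine, and whether a carboxylic acid or an amide in place of the ethyl ester would shift inhibition in this assay.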